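Clearance across the aromatic substituent change

A few compounds are considered here, and "the series" means these few. Any claim that something is new, unique, unknown or untested is made for them only; others in the source may bear on it.

Measured so far in an ADME assay (liver) for metabolic stability, with Liver microsome (Homo sapiens) as the target, using microsomes and NADPH, with a stated time of 30 min, tested at 1 uM; on this read-out higher numbers stand for fast clearance and lower numbers for slow clearance
Compound 1 `Nc1ccc(S(=O)(=O)N2CCN(c3ncc(C(O)(C(F)(F)F)C(F)(F)F)cc3C#CC3CC3)CC2)cn1` gives < 14 mL.min-1.g-1 as a limit of the assay
Compound 2 `Nc1ccc(S(=O)(=O)N2CCN(c3ncc(C(O)(C(F)(F)F)C(F)(F)F)cc3-c3ccncc3)CC2)cn1` gives 15 mL.min-1.g-1 as a number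

In this assay, within the data shown here, compound 2 holds the only number, 15 mL.min-1.g-1 as read. Compound 3 `Cc1ccc(-c2cc(C(O)(C(F)(F)F)C(F)(F)F)cnc2N2CCN(S(=O)(=O)c3ccc(N)nc3)CC2)cn1` has 6-methylpyridin-3-yl in place of pyridin-4-yl on an aromatic carbon on the same aromatic carbon. Among the measured compounds shown here, one measured step bears on this: an at least 1.0-fold higher number from compound 1 to compound 2 (0.02 log units; that floor lies within the scatter) for pyridin-4-yl in place of 2-cyclopropylethynyl, with a limit at one end. On that step, the expected change is small, a 1.1-fold higher number from compound 2 to compound 3 (0.03 log units; within the scatter) in the estimate, and no step beyond the scatter is expected. Compound 3 is estimated at 16 mL.min-1.g-1 (expected range 9 mL.min-1.g-1 to 32 mL.min-1.g-1) in this read-out.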

Compound 3, intrinsic clearance in microsomes: 43 mL.min-1.g-1
Estimate against measurement, compound 3: 2.7-fold (0.43 log units) below; measured number outside the range, above it.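

In this assay, among these compounds, 6-methylpyridin-3-yl in place of pyridin-4-yl gives a 2.9-fold higher number from compound 2 to compound 3 (0.46 log units; beyond the scatter), so this aromatic carbon responds to an exchange between two six-membered aromatic rings, which the earlier compounds did not show. The same group in place of 2-cyclopropylethynyl gives an at least 3.0-fold higher number from compound 1 to compound 3 (0.48 log units; beyond the scatter). Compound 1 holds a limit of the assay, not a number: the limit of < 14 mL.min-1.g-1 in this assay, at which 1 of the 3 values shown sits.

The compounds shown leave open whether the methyl or the changed attachment point of the ring carries the step; the two change together. A pyridin-3-yl group would separate them.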